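Estimating Cytotoxicity of an Aminophenyl Analogue in a Glycosylated Series

The source may hold more compounds than are shown below. What is called first, only, known or untested is meant among the compounds shown, and "the series" means these compounds.

Measured compounds:
compound 1, `CC(=O)OC[C@H]1O[C@@H](n2cc(CN3C(=O)/C(=C\c4ccc(C)cc4)c4ccccc43)nn2)[C@H](OC(C)=O)[C@@H](OC(C)=O)[C@@H]1OC(C)=O`, 9000 nM
compound 2, `CC(=O)OC[C@H]1O[C@@H](n2cc(CN3C(=O)/C(=C\C=C\c4ccccc4)c4ccccc43)nn2)[C@H](OC(C)=O)[C@@H](OC(C)=O)[C@@H]1OC(C)=O`, 25900 nM

Within an ADME assay on NIH3T3 cells (Homo sapiens) for cytotoxicity, read by sulforhodamine B assay, with a stated time of 48 h (a higher number here means a weaker inhibitor, a lower number a stronger inhibitor), compound 2 stands at the highest of the two numbers; its nearest neighbour is compound 1, and the step of a 2.9-fold higher number from compound 1 to compound 2 (0.46 log units; beyond the scatter) lies beyond the scatter. Compound 3, `CC(=O)OC[C@H]1O[C@@H](n2cc(CN3C(=O)/C(=C\c4ccc(N(C)C)cc4)c4ccccc43)nn2)[C@H](OC(C)=O)[C@@H](OC(C)=O)[C@@H]1OC(C)=O`, has not yet been measured. It differs from compound 2 in one place: 4-(dimethylamino)phenyl in place of 2-phenylethenyl on a double-bonded chain carbon bound to a double-bonded ring carbon. Within the data shown here, only one measured step bears on this change, namely a 2.9-fold higher number from compound 1 to compound 2 (0.46 log units; beyond the scatter), which moved from a substituted phenyl to the 2-phenylethenyl chain and raised the number modestly. Compound 3 returns to a substituted phenyl, though with a different substituent than compound 1 carries, so the expected step is a 2.6-fold lower number from compound 2 to compound 3 (0.41 log units; beyond the scatter), a return towards the value of compound 1. The estimate for compound 3 in this assay is 10000 nM, within a range from 4000 nM to 25000 nM.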

Compound 3, half-maximal inhibitory concentration: 17000 nM
Compound 3: the middle estimate sits 1.7-fold (0.23 log units) below what was measured, within the range that was stated.
By their numbers in this assay, from the lowest: compounds 1, 3 and 2 (each within the scatter of the next, the first and the last beyond it).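

In this assay, placing 4-(dimethylamino)phenyl on the double-bonded chain carbon in place of 2-phenylethenyl gives a 1.5-fold lower number from compound 2 to compound 3 (0.18 log units; within the scatter), while dimethylamino in place of methyl on an aromatic carbon gives a 1.9-fold higher number from compound 1 to compound 3 (0.28 log units; within the scatter). Compound 3 therefore cannot be told apart from either neighbour, even though the earlier pair stood clearly apart, with a 2.9-fold higher number from compound 1 to compound 2 (0.46 log units; beyond the scatter), so the two outer compounds are now linked by a compound within the scatter of each. No measurement offered here accounts for any of these steps.

The compounds shown leave open whether a carboxylic acid or a primary amine on the aromatic carbon would give a step beyond the scatter from compound 1. Going by these compounds, it also remains open how an unsubstituted phenyl or a longer chain at this position would compare with compound 2.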